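The compounds below may be only part of what the source reports. "The series", "measured", "known", "first", "only" and "open" are said of these compounds alone.

Compound 1 `CC(C)c1cccc(C(C)C)c1OC(=O)NS(=O)(=O)N1CCCCC1`: in an assay on liver for inhibition of sterol O-acyltransferase 1 (Rattus norvegicus), using microsomes (a higher number here means a weaker inhibitor, a lower number a stronger inhibitor), compound 1 gives > 100000 nM, which is a limit of the assay rather than a number.
Compound 2 `CCCCCCNS(=O)(=O)NC(=O)Oc1c(C(C)C)cccc1C(C)C`: compound 2 gives 21000 nM.
Compound 3 `CCCCN(CCCC)S(=O)(=O)NC(=O)Oc1c(C(C)C)cccc1C(C)C`: compound 3 gives 1900 nM; 1900 nM (2 entries), recorded in two entries.

Among these three, compound 2 stands as the only single number: compound 1 reaches a limit and compound 3 carries two entries. Going by the values given here, the one measured step, an at least 4.7-fold lower number from compound 1 to compound 2 (0.67 log units; beyond the scatter), exchanges the group on the sulfonyl sulfur and is at least modest in size. Compound 4 `CC(C)c1cccc(C(C)C)c1OC(=O)NS(=O)(=O)Nc1ccccc1` differs from compound 2 at a different spot: phenyl in place of hexyl on a sulfonamide nitrogen. Among the compounds with values here, no measured step swaps a chain for an aromatic ring on the sulfonamide nitrogen, so the measured step gives no direct guide, and the values of compounds 2 and 3 show only that the two chain-bearing sulfonamides differ from each other. With so little to lean on, the expected step, a 1.1-fold lower number from compound 2 to compound 4 (0.02 log units; within the scatter), lies within the scatter. The estimated value for compound 4 is 20000 nM, with a range from 5000 nM to 80000 nM.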

Compound 4, half-maximal inhibitory concentration: 38100 nM
Compound 4: middle estimate off by 1.9-fold (0.28 log units), on the low side; measured number inside the range.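

The exchange of hexyl for phenyl on the sulfonamide nitrogen gives a 1.8-fold higher number from compound 2 to compound 4 (0.26 log units; within the scatter), so at this position a chain and an aromatic ring with the same count of heavy atoms cannot be told apart. Anilino in place of piperidin-1-yl gives an at least 2.6-fold lower number from compound 1 to compound 4 (0.41 log units; beyond the scatter), so both hexylamino and anilino now stand on the stronger side of piperidin-1-yl. The true size of that step stays unknown because compound 1 sits at a limit, not a number: the limit of > 100000 nM in this assay, at which 1 of the 4 values shown sits.

On these data alone, whether a benzyl group, a cyclohexyl ring or a longer chain on this nitrogen would shift the number beyond the scatter remains open. Going by these compounds alone, compound 3, with two butyl chains, gives 1900 nM; 1900 nM (2 entries), but no single-place step links it to the other compounds, so its value cannot yet be read against theirs.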